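Trimming the chain of compound 3

The source may hold more compounds than are shown below. What is called first, only, known or untested is meant among the compounds shown, and "the series" means these compounds.

In a functional assay on HL-60 cells (Homo sapiens) for antiproliferative activity, read by MTT assay (a lower number here means a stronger inhibitor, a higher number a weaker inhibitor), only compound 2 (`O[C@@H]1[C@@H](OCc2ccccc2)[C@H](OCc2ccccc2)[C@@H](COCc2ccccc2)O[C@H]1c1ccccc1`) carries a number, at 26300 nM as its reading. Compound 1 (`CCCC[C@H]1O[C@H](COCc2ccccc2)[C@@H](OCc2ccccc2)[C@H](OCc2ccccc2)[C@H]1O`) is reported as "not active" (no number reported) and compound 3 (`CCCCC[C@@H]1O[C@H](COCc2ccccc2)[C@@H](OCc2ccccc2)[C@H](OCc2ccccc2)[C@H]1O`) as "not active" (no number reported) with no single figure to set against compound 2. Compound 4 (`CCCC[C@@H]1O[C@H](COCc2ccccc2)[C@@H](OCc2ccccc2)[C@H](OCc2ccccc2)[C@H]1O`) differs from compound 3 in one place. The change is hydrogen in place of methyl on a saturated chain carbon, four bonds along the chain from a saturated ring carbon and amounts to hydrogen in place of methyl on a saturated chain carbon, four bonds along the chain from a saturated ring carbon. No step beyond the usual scatter is expected, and the likeliest report for compound 4 again carries no number. Should a number appear, compound 4 is estimated at 40000 nM with 15000 nM to 100000 nM as the expected range.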

Compound 4, half-maximal inhibitory concentration: "not active" (no number reported)
Compound 4: no number reported; there is nothing to compare the estimate with.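

In this assay compound 3 gives "not active" (no number reported) and compound 4 gives "not active" (no number reported), so no step can be read between them. Still open is whether chain length or configuration shifts activity at all, with one pair bearing on configuration: the fact that compounds 1 and 4 differ only in the configuration as drawn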